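An Oxime Replaced by an Acetylhydrazone on a Shared Core

This account rests on a few compounds, and the source may have more. Where it says the series, first, only, none or still open, it means among the compounds named here.

Compound 1 `COc1ccc(C(O)c2ccc3c(ccn3C)c2)c(OC)c1OC` carries a hydroxy on the carbon joining its two aromatic parts. In a functional assay on A549 cells (Homo sapiens) for cytotoxicity, read by XTT assay, with a stated time of 72 h (on this read-out higher numbers stand for weaker inhibition and lower numbers for stronger inhibition), compound 1 gives only a limit, > 10000 nM. Within the data shown here, compound 2 `COc1ccc(/C(=N\O)c2ccc3c(ccn3C)c2)c(OC)c1OC` carries an oxime at that carbon instead, and in this assay compound 2 gives 1000 nM, the only actual number in the set. Compound 3 `CCn1ccc2cc(/C(=N/O)c3ccc(OC)c(OC)c3OC)ccc21` differs from compound 2 by methyl in place of hydrogen on a saturated chain carbon bound to an aromatic nitrogen. In this assay compound 3 gives a limit, > 10000 nM. Among the measured compounds shown here, the single measured step, an at least 10-fold higher number from compound 2 to compound 3 (1.00 log units; beyond the scatter), thus runs from the one number up to the limit of > 10000 nM in this assay, at which 2 of the 3 values shown sit.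

Compound 4 `COc1ccc(/C(=N\NC(C)=O)c2ccc3c(ccn3C)c2)c(OC)c1OC` differs from compound 2 by acetamido in place of hydroxy on a double-bonded nitrogen. For the measured compounds named here, no measured step bears on the double-bonded nitrogen; the only step known, an at least 10-fold higher number from compound 2 to compound 3 (1.00 log units; beyond the scatter), concerns the aromatic nitrogen, so it gives no direct guide to this change and is not carried over. With nothing pointing in either direction, compound 4 is expected to sit close to compound 2, with an expected step of a 2.0-fold higher number from compound 2 to compound 4 (0.30 log units; within the scatter) that is small and uncertain. Compound 4 is therefore estimated at 2000 nM, with a range from 500 nM to 10000 nM.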

Compound 4, half-maximal inhibitory concentration: > 10000 nM
Compound 4: no number, only a limit; the forecaster's own chance of this, stated with the estimate: 30%; middle value at least 5.0-fold (0.69 log units) away from the limit.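

Replacing hydroxy with acetamido on the double-bonded nitrogen gives an at least 10-fold higher number from compound 2 to compound 4 (1.00 log units; beyond the scatter) in this assay. Among these compounds, this is the first measured change at this place, as the earlier step concerned only the chain on the aromatic nitrogen. As far as these compounds go, compound 4 gives > 10000 nM, which is a limit of the assay and not a number, so the true size of the step stays unknown. Compound 2, with hydroxy on the double-bonded nitrogen, therefore remains the only compound with an actual number, and both measured steps away from it end at the same limit: the limit of > 10000 nM in this assay, at which 3 of the 4 values shown sit.

The compounds shown leave open whether another group on the double-bonded nitrogen, such as methoxy or an amine, would give an actual number in this assay, or whether the loss extends to every replacement of hydroxy. They also leave open how compound 1, compound 3 and compound 4 rank among themselves, and whether a group such as formamido, shorter than acetamido, would fall between compound 2 and compound 4.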